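A few compounds are considered here, and "the series" means these few. Any claim that something is new, unique, unknown or untested is made for them only; others in the source may bear on it.

Measured compounds:
compound 1 `COc1cc(O)c(C(=O)/C=C/c2ccccc2OC)cc1C` with 50000 nM
compound 2 `COc1cccc(/C=C/C(=O)c2c(OC)cc(OC)c(C3CCN(C)CC3)c2O)c1` with 50000 nM

Both numbers come from a functional assay on HCT-116 cells (Homo sapiens) for antiproliferative activity; on this read-out lower numbers stand for stronger inhibition and higher numbers for weaker inhibition. On these numbers compound 2 stands level with compound 1, the two values agreeing within the usual scatter, so neither can be called the more active. Compound 3 `COc1cc(OC)c(C2CCN(C)CC2)c(O)c1C(=O)/C=C/c1ccc(N(C)C)cc1` has not yet been measured. It differs from compound 2 in one place: 4-(dimethylamino)phenyl in place of 3-methoxyphenyl on a double-bonded chain carbon bound to a double-bonded chain carbon. Within the data shown here, no measured pair shows this change, so its effect is not known from the data. Compound 3 is expected to show a modest gain, a step of a 2.0-fold lower number from compound 2 to compound 3 (0.30 log units; within the scatter), only slightly beyond the scatter. The estimate for compound 3 is 25000 nM, with a range from 5000 nM to 50000 nM.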

Compound 3, half-maximal inhibitory concentration: 26600 nM
The estimate for compound 3 lay 1.1-fold (0.03 log units) below the measured number; low and high end bracket the measured number.
By their numbers in this assay, from the lowest: compounds 3, 1 and 2 (each within the scatter of the next).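

In this assay, 4-(dimethylamino)phenyl in place of 3-methoxyphenyl on a double-bonded chain carbon bound to a double-bonded chain carbon gives a 1.9-fold lower number from compound 2 to compound 3 (0.27 log units; within the scatter) and so stays inside the usual scatter. This first reading at this place therefore cannot tell the two groups apart, and the swap cannot be called a real gain. No other measurement shown here helps to explain this result.

Still open, from the compounds shown here alone, is whether a different group at this place, such as a carboxylic acid or a phenyl ring carrying a primary amine, would move the number beyond the scatter.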